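A few compounds are considered here, and "the series" means these few. Any claim that something is new, unique, unknown or untested is made for them only; others in the source may bear on it.

Working notes on the series. In a functional assay on SK-OV-3 cells (Homo sapiens) for antiproliferative activity, read by MTT assay, with a stated time of 72 h (a lower number here means a stronger inhibitor, a higher number a weaker inhibitor), compound 1 (`CC(C)(C)NC(=O)CCc1cccc2c1B(O)OC2`) gives > 100000 nM, which is a limit and not a number. Going by the values given here, compound 2 (`O=C(CCc1cccc2c1B(O)OC2)Nc1ccc(Cl)cc1`) gives 5000 nM, the only true number so far in this assay.

Compound 3 (`O=C(CCc1cccc2c1B(O)OC2)Nc1cccc(Br)c1`) keeps the shared core and changes one group: 3-bromophenyl in place of 4-chlorophenyl on an amide-type nitrogen. The change is 3-bromophenyl in place of 4-chlorophenyl on an amide-type nitrogen.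

Among the compounds with values here, one measured step bears on this place: an at least 20-fold lower number from compound 1 to compound 2 (1.30 log units; beyond the scatter), a large step with 4-chlorophenyl in place of tert-butyl. It shows that the group on this nitrogen can move the number strongly, but it replaced tert-butyl with a phenyl group. Within the data shown here, compound 2 and compound 3 both carry a substituted phenyl there, and no step between two such groups has been measured. A step of that large size is therefore not carried over to this change.

The estimated step is no change at the digits printed from compound 2 to compound 3 (within the scatter), with no shift beyond the scatter expected in either direction. Compound 3 is expected at 5000 nM, with an estimated range of 1800 nM to 15000 nM.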

Compound 3, half-maximal inhibitory concentration: 540 nM
Compound 3: the middle estimate sits 9.3-fold (0.97 log units) above what was measured, and the stated range ends above it.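

In this assay, the choice between two halogen-bearing phenyl groups on the amide-type nitrogen still moves the number, with a 9.3-fold lower number from compound 2 to compound 3 (0.97 log units; beyond the scatter). This place therefore responds not only to replacing tert-butyl with a phenyl group but also to what the phenyl group carries, and 3-bromophenyl is the better of the two phenyl groups shown here. The wider step, an at least 180-fold lower number from compound 1 to compound 3 (2.26 log units; beyond the scatter), starts from a limit of compound 1 and not from a true number, so its full size stays unknown: the limit of > 100000 nM in this assay, at which 1 of the 3 values shown sits.

The step from 4-chlorophenyl to 3-bromophenyl changes both the halogen and the printed ring position at once, so the compounds shown do not tell which of the two carries it; a 3-chlorophenyl or a 4-bromophenyl group on this nitrogen would separate them. From the compounds shown here alone, it also remains open how a phenyl group carrying an amine or a carboxylic acid would read in this assay, and whether the gain extends to a second halogen on the ring.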